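The source may report more compounds than this note shows. Statements on the series, on what has been measured and on what is new or still open speak of the compounds shown alone.

Measured compounds:
- Compound 1 `NC(=O)CNC(=O)C(CSCc1ccc(Br)cc1)NC(=O)CCC(NC(=O)OCc1ccccc1)C(N)=O`: in a functional assay on K562 cells (Homo sapiens) for cytotoxicity (on this read-out lower numbers stand for stronger inhibition and higher numbers for weaker inhibition), compound 1 gives > 50 uM, which is a limit of the assay and not a number.
- Compound 2 `CCCCOC(=O)CNC(=O)C(CSCc1ccc(Br)cc1)NC(=O)CCC(NC(=O)OCc1ccccc1)C(=O)OCCCC`: compound 2 gives 16.7 uM.
- Compound 3 `COC(=O)CNC(=O)C(CSC(=O)OCc1ccccc1)NC(=O)CCC(NC(=O)OCc1ccccc1)C(=O)OC`: compound 3 gives 1.26 uM.

Among the two numbers that are not limits, compound 2 stands highest; its nearest neighbour is compound 3, whose number lies lower by a gap beyond the usual scatter. Among the compounds with values here, the only other value shown is the limit of compound 1 (the limit of > 50 uM in this assay, at which 1 of the 3 values shown sits).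

The step of interest leads from compound 2 to compound 4 `CCCCOC(=O)CNC(=O)C(CSc1ccc([N+](=O)[O-])cc1[N+](=O)[O-])NC(=O)CCC(NC(=O)OCc1ccccc1)C(=O)OCCCC`, which has not yet been measured. The change is 2,4-dinitrophenyl in place of 4-bromobenzyl on a sulfur, in words: 2,4-dinitrophenyl in place of 4-bromobenzyl on a sulfur. No measured pair of compounds differs in one place, so no step of this kind is known here, and nothing shown gives a cause for any measured difference.

For compound 4 the account expects a step of a 1.4-fold lower number from compound 2 to compound 4 (0.14 log units; within the scatter) from compound 2, that is, no change clearly beyond the scatter, with some lean toward a somewhat lower number. The estimate for compound 4 in this assay is 12 uM, with a range from 3 uM to 50 uM.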

Compound 4, concentration for 50% inhibition: 21.8 uM
Compound 4: middle estimate off by 1.8-fold (0.26 log units), on the low side; measured number inside the range.
By their numbers in this assay, from the lowest: compound 3; then compounds 2 and 4 (each within the scatter of the next). At a limit, above all of these: compound 1.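

In this assay, putting 2,4-dinitrophenyl in place of 4-bromobenzyl on the sulfur gives a 1.3-fold higher number from compound 2 to compound 4 (0.12 log units; within the scatter), the first step shown here that changes one place only. This place on the sulfur therefore takes two quite different groups without a change clearly beyond the scatter: each has one six-membered aromatic ring of carbon only, but 2,4-dinitrophenyl has hydrogen-bond acceptors and 4-bromobenzyl has none. Nothing shown here explains why the read-out stays within the scatter across this change.

As far as these compounds go, it remains open whether the same holds for other groups on this sulfur, such as a plain benzyl without the bromine, a longer alkyl chain or a chain ending in an amine, with the rest of compound 2 kept. From the compounds shown here alone, it is also open whether 2,4-dinitrophenyl would give the same outcome on the core of compound 3 or compound 1, as both differ from compound 2 in more than one place and so cannot show what the ester groups or the group on the sulfur contribute on their own.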